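Swapping the halogen on the indole ring of a terpenoid ester

A few compounds are considered here, and "the series" means these few. Any claim that something is new, unique, unknown or untested is made for them only; others in the source may bear on it.

Compound 3 `COC(=O)[C@@]1(C)CCC=C2[C@@H]1CC[C@@H](C)[C@]2(C)Cc1c(C)[nH]c2ccc(Cl)cc12` gives 18000 nM in a functional assay on WiDr cells (Homo sapiens) for inhibition, read by sulforhodamine B assay, with a stated time of 48 h; on this read-out lower numbers stand for stronger inhibition of growth and higher numbers for weaker inhibition of growth; this is the highest of the three numbers measured. Compound 2 `COC(=O)[C@@]1(C)CCC=C2[C@@H]1CC[C@@H](C)[C@]2(C)Cc1c(C)[nH]c2ccc(Br)cc12` gives 15000 nM, and compound 1 `COC(=O)[C@@]1(C)CCC=C2[C@@H]1CC[C@@H](C)[C@]2(C)Cc1c[nH]c2ccc(F)cc12`, which carries a fluoro and lacks the methyl on the indole, gives 8000 nM. For the measured compounds named here, the step of a 1.2-fold higher number from compound 2 to compound 3 (0.08 log units; within the scatter) is the only direct guide to a halogen swap, and it stays within the scatter. Compound 4 `COC(=O)[C@@]1(C)CCC=C2[C@@H]1CC[C@@H](C)[C@]2(C)Cc1c(C)[nH]c2ccc(F)cc12` differs from compound 3 by fluoro in place of chloro on an aromatic carbon. Because the earlier halogen swap a 1.2-fold higher number from compound 2 to compound 3 (0.08 log units; within the scatter) changed little, no step beyond the scatter is expected here, though the value of compound 1 8000 nM hints the number may drift a little lower. Compound 4 is therefore expected to give 12000 nM, within 5000 nM to 30000 nM, a step of a 1.5-fold lower number from compound 3 to compound 4 (0.18 log units; within the scatter) from compound 3.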

Compound 4, concentration for 50% growth inhibition: 17000 nM
Compound 4: the middle estimate sits 1.4-fold (0.15 log units) below what was measured, and the stated range covers the measured number.
By their numbers in this assay, from the lowest: compounds 1, 2, 4 and 3 (each within the scatter of the next, the first and the last beyond it).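

In this assay the swap to fluoro gives a 1.1-fold lower number from compound 3 to compound 4 (0.02 log units; within the scatter) and a 1.1-fold higher number from compound 2 to compound 4 (0.05 log units; within the scatter) so chloro, bromo and fluoro at this place cannot be told apart. For the compounds shown here, compound 4 also differs from compound 1 only by the methyl, and that single change gives a 2.1-fold higher number from compound 1 to compound 4 (0.33 log units; beyond the scatter) as the only new step beyond the scatter. No measured evidence explains these numbers.

Still open, on these data alone, is whether an amine or a carboxylic acid in place of the halogen would move the number. As far as these compounds go, it is also open whether an ethyl group in place of the methyl would widen or undo that step.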